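The source may hold more compounds than are shown below. What is called first, only, known or untested is meant among the compounds shown, and "the series" means these compounds.

Measured in a functional assay on A549 cells (Homo sapiens) for inhibition, read by MTT assay, with a stated time of 48 h; on this read-out higher numbers stand for weaker inhibition of growth and lower numbers for stronger inhibition of growth:
- Compound 1 `COc1cc(C2=NN(C(=O)c3cccnc3)C(c3cn(C)c4ccc(Br)cc34)C2)cc(OC)c1OC`: > 10000 nM, a limit of the assay and not a number.
- Compound 2 `COc1ccc2c(c1)c(C1CC(c3ccccc3)=NN1C(=O)c1ccc(OC)nc1)cn2C`: 1110 nM
- Compound 3 `COc1ccc2c(c1)c(C1CC(c3ccc(F)cc3)=NN1C(=O)c1ccc(OC)nc1)cn2C`: 710 nM

Compound 3, at 710 nM, lies within the scatter of compound 2, at 1110 nM, so the two cannot be ranked. Compound 4 `COc1ccc2c(c1)c(C1CC(c3ccc(Cl)cc3)=NN1C(=O)c1ccc(OC)nc1)cn2C` has chloro in place of fluoro on an aromatic carbon, para to a large group (chloro in place of fluoro on an aromatic carbon). Among the measured compounds shown here, one measured step bears on this place: a 1.6-fold lower number from compound 2 to compound 3 (0.19 log units; within the scatter), for fluoro in place of hydrogen. That step was small, so no change beyond the scatter is expected in this assay. The expected size is a 1.0-fold lower number from compound 3 to compound 4 (0.02 log units; within the scatter). For compound 4 the estimate is 680 nM, with an expected range of 300 nM to 1500 nM.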

Compound 4, concentration for 50% growth inhibition: 3390 nM
The estimate for compound 4 lay 5.0-fold (0.70 log units) below the measured number, outside the stated range (above it).
By their numbers in this assay, from the lowest: compounds 3 and 2 (each within the scatter of the next); then compound 4. At a limit, above all of these: compound 1.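

Changing fluoro to chloro on this ring gives a 4.8-fold higher number from compound 3 to compound 4 (0.68 log units; beyond the scatter) and so weaker inhibition of growth, which shows that this position can respond to the group placed on it, even though fluoro in place of hydrogen gave a step within the scatter. Chloro in place of hydrogen gives a 3.1-fold higher number from compound 2 to compound 4 (0.48 log units; beyond the scatter) and so points the same way. The values shown offer no measured explanation for this change.

On these data alone, how an amine or a carboxylic acid at this same place would compare with chloro and fluoro remains open.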